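Replacing a bromine-bearing aryl ketone with a fluorine-bearing one

The compounds below may be only part of what the source reports. "The series", "measured", "known", "first", "only" and "open" are said of these compounds alone.

Compound 3 `COc1cc(OC)c(C(=O)c2ccccc2Br)c(O)c1CN1CCCCC1` is the reference point of this account. Within the data shown here, in a functional assay on THP-1 cells (Homo sapiens) for inhibition, read by ELISA, with stated times of 30 min and 24 h, tested at 10 uM (on this read-out higher numbers stand for a stronger effect at the one concentration tested and lower numbers for a weaker effect), compound 3 gives 98%, the highest of the three numbers known so far. The nearest of the others is compound 2 `COc1cc(OC)c(C(=O)c2cccc(Cl)c2)c(O)c1CN1CCCCC1`, which in this assay gives 83%; the furthest is compound 1 `COc1cc(O)c(C(=O)c2cccc(F)c2)c(OC)c1`, which in this assay gives 81%. Among the measured compounds shown here, the only single-point step already measured is a number 15 percentage points higher from compound 2 to compound 3 (beyond the scatter), a change from 3-chlorophenyl to 2-bromophenyl on the carbonyl carbon.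

Compound 4 `COc1cc(OC)c(C(=O)c2cccc(F)c2)c(O)c1CN1CCCCC1` has not yet been measured in this assay. It differs from compound 3 in one place: 3-fluorophenyl in place of 2-bromophenyl on a carbonyl carbon. The measured step from compound 2 to compound 3 bears on this directly, since it too exchanges the aryl group on the carbonyl and moved the read-out upward when 2-bromophenyl entered; the new step runs the other way, taking 2-bromophenyl out again. Compound 1 also carries 3-fluorophenyl on its carbonyl, though on a different core, and its value sits near that of compound 2. Compound 4 is therefore expected to show a step of about a number 16 percentage points lower from compound 3 to compound 4 (beyond the scatter) in this assay, downward, beyond the scatter. The estimate for compound 4 in this assay is 82%, with a range from 70% to 95%.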

Compound 4, a percentage reported as activity, at one concentration (the size of the read-out at that concentration, not a potency): 87%
Beside the measured number, compound 4's estimate is 5 percentage points below it; low and high end bracket the measured number.
By their numbers in this assay, from the lowest: compounds 1, 2 and 4 (each within the scatter of the next); then compound 3.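

In this assay, 3-fluorophenyl in place of 2-bromophenyl on the carbonyl carbon gives a number 11 percentage points lower from compound 3 to compound 4 (beyond the scatter), so 2-bromophenyl now stands clear of two different aryl groups at this position rather than of 3-chlorophenyl alone. Fluoro in place of chloro on the aromatic carbon gives a number 4 percentage points higher from compound 2 to compound 4 (within the scatter), which means that the two halogens cannot be told apart on this read-out and that the drop on leaving 2-bromophenyl is no larger than the one already seen with 3-chlorophenyl. The (piperidin-1-yl)methyl group in place of hydrogen gives a number 6 percentage points higher from compound 1 to compound 4 (within the scatter), so with 3-fluorophenyl on the carbonyl, that group brings no change that can be read at the one concentration tested.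

Nothing at hand explains any of these steps. Going by these compounds, it remains open whether the higher number of compound 3 belongs to the bromine or to the place it occupies on the ring, what a plain phenyl on the carbonyl would give, and whether a morpholine in place of the piperidine, or the same group on a 2-bromophenyl ketone without the amine, would shift the read-out.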